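Swapping the hydrazone aryl group and cell tolerance

The source may report more compounds than this note shows. Statements on the series, on what has been measured and on what is new or still open speak of the compounds shown alone.

Compound 1 `O=C(/C=N/NCc1ccccc1)NCCCCCCCNc1ccnc2cc(Cl)ccc12` and compound 2 `O=C(/C=N/Nc1ccnc2cc(Cl)ccc12)NCCCCCCCNc1ccnc2cc(Cl)ccc12` share one core and differ only in the group on a single amine nitrogen. In a functional assay on MRC5 cells (Homo sapiens) for cytotoxicity, read by colorimetric assay and MTT assay (a lower number here means that less compound is tolerated, a higher number that more compound is tolerated), compound 1 gives 14600 nM, while compound 2 gives 1400 nM. Within the data shown here, the step of a 10-fold lower number from compound 1 to compound 2 (1.02 log units; beyond the scatter) is the only measured comparison available. Compound 2 therefore stands at the lower of the two numbers, meaning that the cells tolerate less of it than of compound 1.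

Compound 3 `O=C(/C=N/Nc1c(Cl)cc(C(F)(F)F)cc1Cl)NCCCCCCCNc1ccnc2cc(Cl)ccc12` differs from compound 2 in one place: 2,6-dichloro-4-(trifluoromethyl)phenyl in place of 7-chloroquinolin-4-yl on an amine nitrogen. Among the measured compounds shown here, the one step that bears on this change is a 10-fold lower number from compound 1 to compound 2 (1.02 log units; beyond the scatter), in which the arrival of the 7-chloroquinolin-4-yl group went with a large drop. Compound 3 removes that group again, but what enters is a substituted phenyl rather than the benzyl of compound 1, so a full return is not assured. The expected step is therefore a moderate rise in this assay, a 3.6-fold higher number from compound 2 to compound 3 (0.55 log units; beyond the scatter). Compound 3 is expected to give about 5000 nM, with a range from 1500 nM to 16000 nM.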

Compound 3, half-maximal cytotoxic concentration: 9200 nM
Estimate against measurement, compound 3: 1.8-fold (0.26 log units) below, within the range that was stated.
By their numbers in this assay, from the lowest: compound 2; then compounds 3 and 1 (each within the scatter of the next).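

Putting 2,6-dichloro-4-(trifluoromethyl)phenyl in place of 7-chloroquinolin-4-yl on this amine nitrogen gives a 6.6-fold higher number from compound 2 to compound 3 (0.82 log units; beyond the scatter) in this assay, which shows that the low number of compound 2 is not simply the result of moving away from benzyl, since a second, quite different group also sits well above it. The two replacement groups cannot be told apart in this assay, as the comparison of the two shows a 1.6-fold lower number from compound 1 to compound 3 (0.20 log units; within the scatter) even though the group in compound 3 carries chlorine and fluorine atoms and the benzyl of compound 1 carries neither, so among these three compounds only the one with 7-chloroquinolin-4-yl stands apart. No measurement available here explains why this group goes with lower cell tolerance.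

As far as these compounds go, it remains open whether a quinolin-4-yl group without its chlorine, or a smaller pyridin-4-yl group, on this nitrogen would stay close to compound 2 or join compound 1 and compound 3. Among these compounds, also open is whether these differences would hold with a shorter chain in place of the one all three compounds share.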